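The source may hold more compounds than are shown below. What is called first, only, known or untested is meant among the compounds shown, and "the series" means these compounds.

Three esters of the shared core, each bearing a hydroxy- or amino-terminated chain on the oxygen next to the carbonyl group, have been run in a functional assay on MT4 cells (Homo sapiens) for cytotoxicity; on this read-out lower numbers stand for higher toxicity in this test and higher numbers for lower toxicity in this test. Compound 1 `Cc1cn(C2CC(N=[N+]=[N-])C(COC(=O)OCCCCCCCCO)O2)c(=O)[nH]c1=O` gives in this assay only a limit, > 50000 nM. Compound 2 `Cc1cn(C2CC(N=[N+]=[N-])C(COC(=O)OCCCCO)O2)c(=O)[nH]c1=O`, the 4-hydroxybutyl member, likewise gives in this assay only a limit, > 50000 nM. Compound 3 `Cc1cn(C2CC(N=[N+]=[N-])C(COC(=O)OCCCN)O2)c(=O)[nH]c1=O`, the 3-aminopropyl member, gives in this assay only a limit as well, > 50000 nM. Compound 3 therefore stands where the other two stand, at the ceiling of the assay; the steps a step that the two limits leave unreadable from compound 1 to compound 3 and a step that the two limits leave unreadable from compound 2 to compound 3 cannot be sized, and neither can a step that the two limits leave unreadable from compound 1 to compound 2. All that the numbers show is the limit of > 50000 nM in this assay, at which 3 of the 3 values shown sit.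

The next member, compound 4 `Cc1cn(C2CC(N=[N+]=[N-])C(COC(=O)OCCCCCO)O2)c(=O)[nH]c1=O`, carries the 5-hydroxypentyl chain. Against compound 3 the change is 2-hydroxyethyl in place of amino on a saturated chain carbon, three bonds along the chain from an oxygen next to a carbonyl group. The swaps between amino- and hydroxy-terminated chains from compound 1 to compound 3 and from compound 2 to compound 3 gave no readable step, and the shortening from compound 1 to compound 2 gave none either. Compound 4 is therefore expected to remain at the limit, with an estimated step that the limit leaves unreadable from compound 3 to compound 4. The estimate for compound 4 in this assay is 60000 nM, between 30000 nM and 200000 nM, most likely to be reported again only as a limit.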

Compound 4, half-maximal cytotoxic concentration: > 50000 nM
Compound 4 gave a limit, no number; the forecaster's own chance of this, stated with the estimate: 90%; the middle value is on the limit's open side.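

In this assay compound 4 gives only a limit (> 50000 nM). Among the compounds shown here, no step from compound 1, compound 2 or compound 3 to compound 4 can be read. The compounds shown leave open at what concentration, if any, these hydroxy- or amino-terminated chains would give a measurable value in this assay.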